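The source may report more compounds than this note shows. Statements on the series, on what has been measured and on what is new or still open speak of the compounds shown alone.

The measured compounds are compound 1 `COc1cc2c(Nc3nc4ccc(C(=O)Nc5c(C)cc(C)cc5C)cc4s3)ncnc2cc1OCCCN1CCCCC1C` with 3600 nM, compound 2 `CCN(CC)CCCOc1cc2ncnc(Nc3nc4ccc(C(=O)Nc5c(C)cccc5Cl)cc4s3)c2cc1OC` with 7300 nM, and compound 3 `CCN(CC)CCCOc1cc2ncnc(Nc3nc4ccc(C(=O)Nc5c(C)cc(C)cc5C)cc4s3)c2cc1OC` with 4300 nM.

In a functional assay on U-937 cells (Homo sapiens) for cytotoxicity, read by WST assay, with a stated time of 72 h (on this read-out lower numbers stand for stronger inhibition and higher numbers for weaker inhibition), compound 3 stands second highest of the three numbers; compound 1 gives 3600 nM and compound 2 gives 7300 nM, each within the scatter of compound 3. Compound 4 `COc1cc2c(Nc3nc4ccc(C(=O)Nc5c(C)cc(C)cc5C)cc4s3)ncnc2cc1OCCCN1CCCC1` differs from compound 3 by pyrrolidin-1-yl in place of diethylamino on a saturated chain carbon, three bonds along the chain from an oxygen on an aromatic ring. The step that bears on this is a 1.2-fold higher number from compound 1 to compound 3 (0.08 log units; within the scatter), an exchange on the same saturated chain carbon, which stayed within the scatter. The step of a 1.7-fold lower number from compound 2 to compound 3 (0.23 log units; within the scatter) touches a different part of the molecule and says nothing about the amine. Compound 4 is therefore expected to show no step beyond the scatter in this assay: a 1.1-fold lower number from compound 3 to compound 4 (0.03 log units; within the scatter). Compound 4 is estimated at 4000 nM, within 2000 nM to 8000 nM.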

Compound 4, half-maximal inhibitory concentration: 4600 nM
The estimate for compound 4 lay 1.2-fold (0.06 log units) below the measured number, and the stated range covers the measured number.
By their numbers in this assay, from the lowest: compounds 1, 3, 4 and 2 (each within the scatter of the next, the first and the last beyond it).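

In this assay, pyrrolidin-1-yl in place of diethylamino on the saturated chain carbon gives a 1.1-fold higher number from compound 3 to compound 4 (0.03 log units; within the scatter), and pyrrolidin-1-yl in place of 2-methylpiperidin-1-yl gives a 1.3-fold higher number from compound 1 to compound 4 (0.11 log units; within the scatter), both within the scatter. The position thus takes a five-membered ring amine as well as the two amines seen before, and the three cannot be told apart in this assay. Nothing measured here offers an explanation for this. Still open, going by these compounds, is whether a morpholine or a piperazine in this place, or a longer chain carrying the pyrrolidin-1-yl group, would give a step beyond the scatter.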